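A few compounds are considered here, and "the series" means these few. Any claim that something is new, unique, unknown or untested is made for them only; others in the source may bear on it.

In a functional assay on KM12 cells (Homo sapiens) for inhibition, read by sulforhodamine B assay, with a stated time of 48 h, tested at 10 uM (on this read-out higher numbers stand for more inhibition of growth at the one concentration tested and lower numbers for less inhibition of growth), three compounds have been measured so far. Compound 1 `COc1cc(-c2nc(N)n(CC(=O)Nc3ccc(/C(C)=N\O)cc3)n2)cc(OC)c1OC` gives 2.75%. Compound 2 `c1ccc(-c2nc3sc(-c4ccccc4)cn3n2)cc1` gives 18%, and compound 3 `COc1cc(-c2nc3sc(-c4ccccc4)cn3n2)cc(OC)c1OC` gives 14%. Compound 2 holds the highest of the three numbers; its number and that of compound 3 lie within the scatter of each other, while the number of compound 1 stands beyond the scatter below it. Compound 4 `Clc1ccc(-c2cn3nc(-c4ccccc4)nc3s2)cc1` has not yet been measured. It differs from compound 2 in one place: chloro in place of hydrogen on an aromatic carbon, so that a phenyl becomes a 4-chlorophenyl. For the measured compounds named here, with no step between measured compounds to lean on, only a small step in this assay is expected, within the scatter, in either direction. Compound 4 is therefore estimated at 22%, within a range from 5% to 40%. That estimate means an expected step of a number 4 percentage points higher from compound 2 to compound 4 (within the scatter).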

Compound 4, percent growth inhibition at one concentration: 30%
Beside the measured number, compound 4's estimate is 8 percentage points below it; measured number inside the range.
By their numbers in this assay, from the lowest: compound 1; then compounds 3 and 2 (each within the scatter of the next); then compound 4.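

In this assay, for the compounds shown here, chloro in place of hydrogen gives a number 12 percentage points higher from compound 2 to compound 4 (beyond the scatter), the first step in this set that can be read from a change in one place. It shows that growth inhibition at the one concentration tested responds to a change at this position, on an aromatic carbon para to a large group. Nothing available explains this rise.

On these data alone, whether an amine or a carboxylic acid at this position would give a similar step remains open. So does whether chloro would give the same step on the other phenyl or on compound 3.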